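Amide variation on the shared flavonol core

The source may hold more compounds than are shown below. What is called first, only, known or untested is meant among the compounds shown, and "the series" means these compounds.

Measured so far in a functional assay on MDA-MB-231 cells (Homo sapiens) for antiproliferative activity, read by CCK-8 assay, with a stated time of 72 h; on this read-out higher numbers stand for weaker inhibition and lower numbers for stronger inhibition:
compound 1 `Cc1cccc(C(=O)Nc2cccc(-c3oc4cc(-c5ccc(F)cc5)ccc4c(=O)c3O)c2)c1`: 2840 nM
compound 2 `CCc1ccc(C(=O)Nc2cccc(-c3oc4cc(-c5ccc(F)cc5)ccc4c(=O)c3O)c2)cc1`: 9070 nM
compound 3 `O=C(Nc1cccc(-c2oc3cc(-c4ccc(F)cc4)ccc3c(=O)c2O)c1)c1ccc(Cl)nc1`: 1760 nM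

Compound 3 carries the lowest number of the three; the gap to compound 1 lies within the scatter (a 1.6-fold lower number from compound 1 to compound 3 (0.21 log units; within the scatter)), while the gap to compound 2 is beyond it (a 5.2-fold lower number from compound 2 to compound 3 (0.71 log units; beyond the scatter)). Compound 4 `O=C(Nc1cccc(-c2oc3cc(-c4ccc(F)cc4)ccc3c(=O)c2O)c1)c1ccc(-c2ccccc2)cc1` differs from compound 3 by 4-phenylphenyl in place of 6-chloropyridin-3-yl on a carbonyl carbon. For the measured compounds named here, no measured step replaces a six-membered aromatic ring with one hetero atom by two carbon-only rings, so the step from compound 1 to compound 2 (a 3.2-fold higher number from compound 1 to compound 2 (0.50 log units; beyond the scatter)) and the step to compound 3 (a 5.2-fold lower number from compound 2 to compound 3 (0.71 log units; beyond the scatter)) are the only bearings. A modest rise is expected, a 2.8-fold higher number from compound 3 to compound 4 (0.45 log units; beyond the scatter). Compound 4 is estimated at 5000 nM, range 1500 nM to 16000 nM.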

Compound 4, half-maximal inhibitory concentration: 63200 nM
Compound 4: the middle estimate sits 13-fold (1.10 log units) below what was measured, outside the stated range (above it).
By their numbers in this assay, from the lowest: compounds 3 and 1 (each within the scatter of the next); then compound 2; then compound 4.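

With 4-phenylphenyl on the carbonyl carbon, the series shows its first large losses: a 36-fold higher number from compound 3 to compound 4 (1.56 log units; beyond the scatter) and a 22-fold higher number from compound 1 to compound 4 (1.35 log units; beyond the scatter), whereas earlier steps among the single-ring groups were modest at most. Phenyl in place of ethyl on an aromatic carbon also gives a 7.0-fold higher number from compound 2 to compound 4 (0.84 log units; beyond the scatter), so the outer carbon-only ring raises the number even against the 4-ethylphenyl group. No measured evidence available here accounts for this rise. From the compounds shown here alone, whether a cyclohexyl or a piperidine in place of that outer phenyl would bring the number back towards that of compound 3 remains open.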